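Lengthening the Sulfonyl Alkyl Chain of a Catechol Vinyl Sulfone

A few compounds are considered here, and "the series" means these few. Any claim that something is new, unique, unknown or untested is made for them only; others in the source may bear on it.

Measured compounds:
- compound 1, `O=S(=O)(/C=C/c1ccc(O)c(O)c1)CC1CCC1`: 8800 nM
- compound 2, `O=S(=O)(/C=C/c1ccc(O)c(O)c1)CCCc1ccccc1`: 11500 nM
- compound 3, `CCCCCCS(=O)(=O)/C=C/c1ccc(O)c(O)c1`: 7300 nM

These three share a core and differ only in the group on the saturated chain carbon bound to the sulfonyl sulfur. In a functional assay, read by fluorescence and spectrophotometry, with a stated time of 1 h (on this read-out higher numbers stand for an effect only at larger amounts of compound and lower numbers for an effect already at smaller amounts), compound 1 gives the second highest of the three numbers, but the spread is small: the step of a 1.2-fold lower number from compound 1 to compound 3 (0.08 log units; within the scatter) lies within the scatter, and compound 2, with 11500 nM, is likewise within the scatter of compound 1.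

Compound 4, `CCCCCCCCS(=O)(=O)/C=C/c1ccc(O)c(O)c1`, has not yet been measured in this assay. It differs from compound 1 by heptyl in place of cyclobutyl on a saturated chain carbon bound to a sulfonyl sulfur. The step that bears most directly on it is a 1.2-fold lower number from compound 1 to compound 3 (0.08 log units; within the scatter), where a straight chain in place of the ring made no difference beyond the scatter; the step of a 1.6-fold lower number from compound 2 to compound 3 (0.20 log units; within the scatter) points the same way. Among the compounds with values here, nothing among the measured compounds suggests that a longer straight chain should move the number beyond the scatter in either direction.

Compound 4 is therefore expected to give about 7000 nM, with a range from 3000 nM to 16000 nM. For compound 4 this estimate means an expected step of a 1.3-fold lower number from compound 1 to compound 4 (0.10 log units; within the scatter).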

Compound 4, half-maximal effective concentration: 6400 nM
For compound 4 the middle estimate is 1.1-fold (0.04 log units) above the measured one; the range from low to high includes it.
By their numbers in this assay, from the lowest: compounds 4, 3, 1 and 2 (each within the scatter of the next).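

Compound 4 extends the series to the longest straight chain shown, and in this assay even this change leaves the number within the scatter of the cyclobutyl compound (a 1.4-fold lower number from compound 1 to compound 4 (0.14 log units; within the scatter)). Ethyl in place of hydrogen on a saturated chain carbon, six bonds along the chain from a sulfonyl sulfur, also stays within the scatter (a 1.1-fold lower number from compound 3 to compound 4 (0.06 log units; within the scatter)). The widest gap among these compounds is again within the scatter (a 1.8-fold lower number from compound 2 to compound 4 (0.25 log units; within the scatter)), so this position has so far tolerated rings and straight chains alike.

As far as these compounds go, it remains open whether a longer chain, an amine or a carboxylic acid in place of heptyl would give a step beyond the scatter. No supporting evidence bears on why these numbers lie so close together.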